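Trifluoromethylphenyl urea as successor to a dichlorophenyl urea

The source may hold more compounds than are shown below. What is called first, only, known or untested is meant among the compounds shown, and "the series" means these compounds.

Going by the values given here, the two compounds measured so far share one core and differ only in the group attached to the carbonyl. Compound 1 `COc1cc(Cl)cc(-c2nn(-c3cccc(NC(=O)c4ccc(Cl)c(Cl)c4)c3)cc2-c2ccncc2)c1` carries a 3,4-dichlorophenyl on the carbonyl carbon; in a functional assay on RPMI-8226 cells (Homo sapiens) for inhibition, read by sulforhodamine B assay, with a stated time of 48 h, tested at 10 uM (on this read-out higher numbers stand for a weaker effect at the one concentration tested and lower numbers for a stronger effect), compound 1 gives 46%. Compound 2 `COc1cc(Cl)cc(-c2nn(-c3cccc(NC(=O)Nc4ccc(Cl)c(Cl)c4)c3)cc2-c2ccncc2)c1` carries (3,4-dichlorophenyl)amino in that place, and in this assay compound 2 gives -4.44%. Among the compounds with values here, the step of a number 50.4 percentage points lower from compound 1 to compound 2 (beyond the scatter) is the only measured step in the set, and it leaves compound 2 with the lowest of the two numbers, the stronger effect at the single concentration tested.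

Compound 3 `COc1cc(Cl)cc(-c2nn(-c3cccc(NC(=O)Nc4cccc(C(F)(F)F)c4)c3)cc2-c2ccncc2)c1` keeps the urea of compound 2 and changes only the aryl on the amide-type nitrogen: 3-(trifluoromethyl)phenyl in place of 3,4-dichlorophenyl on an amide-type nitrogen. Within the data shown here, no measured step bears on this exchange; the one step recorded concerns the carbonyl side and not the aryl on the nitrogen, so nothing in the data fixes the direction of the change. With compound 2 already at -4.44%, the expected step of a number 9.4 percentage points higher from compound 2 to compound 3 (within the scatter) in this assay is none beyond the scatter, with the range left open upward. Compound 3 is therefore estimated at 5%, between -15% and 40%.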

Compound 3, a percentage reported as activity, at one concentration (the size of the read-out at that concentration, not a potency): -14.2%
Estimate against measurement, compound 3: 19.2 percentage points above, within the range that was stated.
By their numbers in this assay, from the lowest: compounds 3 and 2 (each within the scatter of the next); then compound 1.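

In this assay, 3-(trifluoromethyl)phenyl in place of 3,4-dichlorophenyl on the amide-type nitrogen gives a number 9.8 percentage points lower from compound 2 to compound 3 (within the scatter), so the two ureas cannot be told apart at this concentration, although the entering aryl group counts 10 heavy atoms against 8. The low number thus does not depend on the 3,4-dichlorophenyl group: with the new aryl group, the urea still gives a number 60.2 percentage points lower from compound 1 to compound 3 (beyond the scatter), a large step beyond the scatter, and neither urea among these compounds goes against this. The data offer nothing that explains these numbers.

The compounds shown leave open how far this tolerance on the nitrogen extends, for instance to a pyridyl or cyclohexyl group in place of the substituted phenyl, and whether a thiourea or a sulfonamide could take over from the urea. With only one concentration in this assay, they also leave open whether compound 2 and compound 3 would differ in the strength of their effect at other concentrations.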